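A Dimethoxyphenyl Variant Weighed Against Two Measured Analogues

The source may hold more compounds than are shown below. What is called first, only, known or untested is meant among the compounds shown, and "the series" means these compounds.

Compound 1 `CN(C)CCn1c(=O)c(=Cc2ccc(F)c(F)c2)s/c1=C1\C(=O)Nc2cc(F)ccc21`: 6400 nM
Compound 2 `CN(C)CCn1c(=O)c(=Cc2ccc(C=O)c(C=O)c2)s/c1=C1\C(=O)Nc2cc(F)ccc21`: 2810 nM

Two compounds have been run in a functional assay on NCI-H460 cells (Homo sapiens) for inhibition, read by MTT assay, with a stated time of 72 h; a higher number here means a weaker inhibitor, a lower number a stronger inhibitor. Compound 1 gives 6400 nM and compound 2 gives 2810 nM. Among the compounds with values here, compound 2 therefore holds the lowest number of the two, with the step of a 2.3-fold lower number from compound 1 to compound 2 (0.36 log units; beyond the scatter) setting it apart from its only neighbour.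

Compound 3 `COc1ccc(OC)c(C=c2s/c(=C3\C(=O)Nc4cc(F)ccc43)n(CCN(C)C)c2=O)c1` has not yet been measured. It differs from compound 2 as follows: 2,5-dimethoxyphenyl in place of 3,4-diformylphenyl on a double-bonded chain carbon bound to an aromatic carbon. Within the data shown here, the only measured step, a 2.3-fold lower number from compound 1 to compound 2 (0.36 log units; beyond the scatter), changes the same aryl group at the same place, and it was modest in size. That step concerns a different pair of substituents, so it says little about the direction for the dimethoxy pattern; what it does show is that swapping groups on this ring moved the number only modestly. Compound 3 is therefore expected to sit close to compound 2, with the step of a 1.4-fold higher number from compound 2 to compound 3 (0.15 log units; within the scatter) estimated as small and of uncertain direction. For compound 3 the expected value in this assay is 4000 nM, within a range from 1500 nM to 12000 nM.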

Compound 3, half-maximal inhibitory concentration: 7150 nM
Beside the measured number, compound 3's estimate is 1.8-fold (0.25 log units) below it, within the range that was stated.
By their numbers in this assay, from the lowest: compound 2; then compounds 1 and 3 (each within the scatter of the next).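

In this assay, the 2,5-dimethoxyphenyl group shows that the lower number of compound 2 does not extend to every replacement on the double-bonded chain carbon bound to an aromatic carbon, as this change gives a 2.5-fold higher number from compound 2 to compound 3 (0.41 log units; beyond the scatter). The second comparison, a 1.1-fold higher number from compound 1 to compound 3 (0.05 log units; within the scatter), places the 2,5-dimethoxyphenyl and 3,4-difluorophenyl groups level with each other, so that among these three aryl groups only the 3,4-diformylphenyl group stands apart, with both of its steps beyond the scatter. Nothing available explains this difference between the aryl groups.

The compounds shown leave open whether it is the formyl groups themselves or their arrangement on the ring that sets compound 2 apart, a question that a 3,4-dimethoxyphenyl group at this place could help to settle. They also leave open how an aryl group carrying an amine or a carboxylic acid would read here, and whether the separation of compound 2 from the other two compounds would carry over to other cell lines.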